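Working notes: butyl extension from compound 3 to compound 4

A few compounds are considered here, and "the series" means these few. Any claim that something is new, unique, unknown or untested is made for them only; others in the source may bear on it.

Three compounds carry results in a functional assay on L1210 cells (Mus musculus) for cytotoxicity, with a stated time of 48 h; a higher number here means a weaker inhibitor, a lower number a stronger inhibitor. Compound 1 `C=C1CC(c2ccc(Br)cc2)N(C)C1=O` gives only a limit there, > 50000 nM. Compound 2 `C=C1CC(c2ccc(OC)cc2)N(C)C1=O` likewise gives only a limit, > 50000 nM. For the measured compounds named here, the single step between measured compounds, a step that the two limits leave unreadable from compound 1 to compound 2, is therefore unreadable, and the limit of > 50000 nM in this assay, at which 2 of the 3 values shown sit, marks where those two entries rest. Going by the values given here, compound 3 `C=C1CC(C)OC1=O` is the only compound with an actual number in this assay, giving 32500 nM. The entries for compound 1 and compound 2 are limits, so compound 3 cannot be ordered against either of them.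

Compound 4 `C=C1CC(CCCCC)OC1=O` differs from compound 3 by butyl in place of hydrogen on a saturated chain carbon bound to a saturated ring carbon. Among the compounds with values here, no measured step bears on a change of this kind: the one measured step concerns an aromatic substituent absent from the core of compound 3, and its size is hidden behind the limits. The expectation for compound 4 in this assay rests on the reading of compound 3 alone, and the change is taken as a modest expected gain, a 3.3-fold lower number from compound 3 to compound 4 (0.51 log units; beyond the scatter), an estimate rather than a measurement. Compound 4 is expected to give about 10000 nM in this assay, within an estimated range of 2000 nM to 40000 nM.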

Compound 4, half-maximal inhibitory concentration: 20000 nM
The estimate for compound 4 lay 2.0-fold (0.30 log units) below the measured number, and the stated range covers the measured number.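

In this assay, for the compounds shown here, butyl in place of hydrogen on a saturated chain carbon bound to a saturated ring carbon gives a 1.6-fold lower number from compound 3 to compound 4 (0.21 log units; within the scatter) and is the first step whose size can be read. Going by these compounds alone, the two compounds therefore stand level at this place, and the core of compound 3 carries the butyl group and still returns a number rather than a limit, which the earlier compounds could not show for any change. The compounds shown offer nothing that accounts for this step.

On these data alone, whether a longer chain such as octyl, or a butyl chain ending in an amine or a carboxylic acid, would move the number beyond the scatter at this place remains open, since a single step within the scatter fixes no trend with chain length. Also open, as far as these compounds go, is how a phenyl group on the saturated ring carbon of the core of compound 3 would read, which would show whether an aromatic group at that place returns a number in this assay on this core.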